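A few compounds are considered here, and "the series" means these few. Any claim that something is new, unique, unknown or untested is made for them only; others in the source may bear on it.

Of the compounds shown here, two have been measured in an assay on isolated protein for inhibition of hexokinase-1 (Rattus norvegicus), with a stated time of 6 h, tested at 10 mM; a lower number here means less inhibition, a higher number more inhibition at the concentration tested (going by the name of the read-out). Going by the values given here, compound 1, `Nc1ncnc2c1nc(NCCCCCCCCNC(=O)CI)n2[C@@H]1O[C@H](COP(=O)(O)OP(=O)(O)OP(=O)(O)O)[C@@H](O)[C@H]1O`, is the one with an amino group on its shared core. In this assay compound 1 gives 0%. Compound 2, `O=C(CI)NCCCCCCCCNc1ncnc2c1ncn2[C@@H]1O[C@H](COP(=O)(O)OP(=O)(O)OP(=O)(O)O)[C@@H](O)[C@H]1O`, lacks that amino group. In this assay compound 2 gives 35%, which is the higher of the two numbers, and the gap to compound 1 lies beyond the usual scatter of such measurements.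

The next compound, compound 3, `CC(=O)NCCCCCCCCNc1ncnc2c1ncn2[C@@H]1O[C@H](COP(=O)(O)OP(=O)(O)OP(=O)(O)O)[C@@H](O)[C@H]1O`, has not been measured in this assay. Compared with compound 2 the change is hydrogen in place of iodo on a saturated chain carbon bound to a carbonyl carbon, so the halogen at the end of the chain is simply gone. Among the compounds with values here, no measured pair shows this kind of change, so no step size is known from the data. The expected step from compound 2 to compound 3 in this assay is a number 23 percentage points lower from compound 2 to compound 3 (beyond the scatter), a drop of moderate size. Compound 3 is therefore expected to give about 12%, with a likely range from 0% to 35%.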

Compound 3, a percentage reported as inhibition, at one concentration (the size of the read-out at that concentration, not a potency): 0%
The estimate for compound 3 lay 12 percentage points above the measured number, and the stated range covers the measured number.
By their numbers in this assay, from the lowest: compounds 1 and 3 (each within the scatter of the next); then compound 2.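

Replacing iodo with hydrogen on a saturated chain carbon bound to a carbonyl carbon gives a number 35 percentage points lower from compound 2 to compound 3 (beyond the scatter) in this assay, the first step known for this position. Compound 3 gives 0%, so with the rest of the structure unchanged, the inhibition seen for compound 2 is not retained once iodo is gone and the ((iodomethyl)carbonyl)amino group has become acetamido. The data shown offer no explanation for this step.

Going by these compounds, it remains open whether chloro or bromo on the same carbon would keep any of the inhibition, and whether iodo would still give inhibition on a shorter or longer chain. Each compound here has a reading at one concentration only, so these numbers show the size of the inhibition at that concentration and give no potency.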